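Nitro for methyl on the aryl of compound 2

The source may hold more compounds than are shown below. What is called first, only, known or untested is meant among the compounds shown, and "the series" means these compounds.

Measured compounds:
compound 1 `CC(C)NC1CC(=O)N(c2ccc(F)c(Cl)c2)C1OCC(F)(F)F` > 100000 nM
compound 2 `Cc1ccc(N2C(=O)C=CC2OCC(F)(F)F)cc1` 13700 nM

For the measured compounds named here, compound 2 is the only compound with a number in a functional assay on A549 cells (Homo sapiens) for inhibition; a higher number here means a weaker inhibitor, a lower number a stronger inhibitor; in this assay compound 2 gives 13700 nM. For compound 1 the result is a limit of the assay and not a number, (the limit of > 100000 nM in this assay, at which 1 of the 2 values shown sits). Going by the values given here, no two measured compounds differ in one place, so no measured step is available.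

Compound 3 `O=C1C=CC(OCC(F)(F)F)N1c1ccc([N+](=O)[O-])cc1` differs from compound 2 by nitro in place of methyl on an aromatic carbon. Among the compounds with values here, with no measured step to lean on, the size and direction of the change in this assay are open; no change beyond the usual scatter is expected as the central case, with a wide range around it. Compound 3 is expected to give about 10000 nM in this assay, between 2000 nM and 60000 nM, a step from compound 2 to compound 3 of a 1.4-fold lower number from compound 2 to compound 3 (0.14 log units; within the scatter).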

Compound 3, half-maximal inhibitory concentration: 3270 nM
Beside the measured number, compound 3's estimate is 3.1-fold (0.49 log units) above it, within the range that was stated.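

In this assay, for the compounds shown here, the replacement of methyl by nitro gives a 4.2-fold lower number from compound 2 to compound 3 (0.62 log units; beyond the scatter), the first measured step. The aromatic carbon para to a large group is therefore a place where a single change moves the number beyond the scatter, with nitro giving the lower number in this one pair. No measurement shown here accounts for the step.

As far as these compounds go, whether an amine, a carboxylic acid or a nitrile at this aromatic carbon would give a lower or higher number than nitro stays open, and one pair sets no trend. Going by these compounds alone, compound 1 differs from compound 2 and compound 3 in more than one place and offers no step, its result being a limit of the assay and not a number: the limit of > 100000 nM in this assay, at which 1 of the 3 values shown sits.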